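The source may report more compounds than this note shows. Statements on the series, on what has been measured and on what is new or still open speak of the compounds shown alone.

Measured in a functional assay on A549 cells (Homo sapiens) for antiproliferative activity, read by MTT assay, with a stated time of 48 h; a lower number here means a stronger inhibitor, a higher number a weaker inhibitor:
Compound 1 `Cn1cc(C2=C(c3nn(CCCN4CCCCC4)c4ncccc34)C(=O)N(c3ccccc3)C2=O)c2ccccc21`: 20600 nM
Compound 2 `Cn1cc(C2=C(c3nn(CCCN4CCCCC4)c4ncccc34)C(=O)N(c3cccc4ccccc34)C2=O)c2ccccc21`: 2820 nM
Compound 3 `Cn1cc(C2=C(c3nn(CCCN4CCCCC4)c4ncccc34)C(=O)NC2=O)c2ccccc21`: > 100000 nM, which is a limit of the assay

Of the two values that are true numbers, compound 2 holds the lower one, the step being a 7.3-fold lower number from compound 1 to compound 2 (0.86 log units; beyond the scatter). Compound 4 `Cn1cc(C2=C(c3n[nH]c4ncccc34)C(=O)N(c3cccc4ccccc34)C2=O)c2ccccc21` differs from it by hydrogen in place of 3-(piperidin-1-yl)propyl on an aromatic nitrogen. Among the compounds with values here, no measured step touches this place. All three change the group on an amide-type nitrogen in a ring, so they bear on it only loosely. There, putting hydrogen in place of a large group gave an at least 35-fold higher number from compound 2 to compound 3 (1.54 log units; beyond the scatter) and an at least 4.8-fold higher number from compound 1 to compound 3 (0.68 log units; beyond the scatter). On that analogy, a modest, uncertain rise in this assay is expected. The estimated step is a 2.8-fold higher number from compound 2 to compound 4 (0.45 log units; beyond the scatter). The expected value for compound 4 is 8000 nM, with an estimated range of 1500 nM to 50000 nM.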

Compound 4, half-maximal inhibitory concentration: > 100000 nM
Compound 4: no number, only a limit (the forecaster's own chance of this, stated with the estimate: 15%); at least 12-fold (1.09 log units) between middle value and limit.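

In this assay, the only step shown at this position, hydrogen in place of 3-(piperidin-1-yl)propyl on the aromatic nitrogen, gives an at least 35-fold higher number from compound 2 to compound 4 (1.54 log units; beyond the scatter). Compound 2 therefore keeps a measurable number only with this chain present, and naphthalen-1-yl on the amide-type nitrogen does not suffice alone. Compound 4 gives only a limit of the assay, so this step has no upper bound: the limit of > 100000 nM in this assay, at which 2 of the 4 values shown sit.

Going by these compounds, it remains open which part of the chain matters. A methyl group, a shorter or longer chain, or morpholin-4-yl in place of piperidin-1-yl could each separate these.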